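The source may hold more compounds than are shown below. What is called first, only, known or untested is meant among the compounds shown, and "the series" means these compounds.

Compound 1 `Cc1ccc(NC(=O)N[C@H](C)c2ccccc2)cc1` is the starting point. In an ADME assay on the whole organism with Oryza sativa as the target, tested at 10 uM (on this read-out higher numbers stand for a weaker effect at the one concentration tested and lower numbers for a stronger effect), compound 1 gives 64%, the lowest of the three numbers here, that is, the strongest effect at the one concentration tested. Compound 2 `Cc1ccc(NC(=O)N[C@@H](C)c2ccccc2)cc1` gives 100%, and a number 36 percentage points higher from compound 1 to compound 2 (beyond the scatter), which rests on (the fact that compounds 1 and 2 differ only in the configuration as drawn). Compound 3 `CCc1ccccc1NC(=O)N[C@H](C)c1ccccc1` gives 92%. Compound 4 `CC(C)c1ccc(NC(=O)N[C@H](C)c2ccccc2)cc1` arises from compound 1 by a single change: isopropyl in place of methyl on an aromatic carbon. Among the compounds with values here, none of the measured steps exchanges one group for another on the shared core, so no measured step gauges this change, and in this assay no step beyond the scatter is expected. The value estimated for compound 4 is 70%, within a range from 50% to 95%, meaning an expected step of a number 6 percentage points higher from compound 1 to compound 4 (within the scatter).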

Compound 4, a percentage reported as activity, at one concentration (the size of the read-out at that concentration, not a potency): 49%
The estimate for compound 4 lay 21 percentage points above the measured number, and the stated range ends above it.
By their numbers in this assay, from the lowest: compound 4; then compound 1; then compounds 3 and 2 (each within the scatter of the next).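

Isopropyl in place of methyl on this aromatic carbon, para to a large group, gives in this assay a number 15 percentage points lower from compound 1 to compound 4 (beyond the scatter) and so a stronger effect at the one concentration tested. Within the data shown here, this is the first measured step that exchanges one group for another on the shared core, and it shows that the larger group at this position keeps the effect rather than losing it. Nothing in the available evidence bears on why this step occurs. Going by these compounds, whether a tert-butyl group or a longer chain would lower the number further stays open, as does what an amine or a carboxylic acid would do at this position.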